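A few compounds are considered here, and "the series" means these few. Any claim that something is new, unique, unknown or untested is made for them only; others in the source may bear on it.

The series shares the core of compound 1 `O=C(Nc1ccc(S(=O)(=O)NC2CC2)cc1)C1C(C(=O)O)[C@H]2CC[C@@H]1O2`, which in a functional assay on HepG2 cells (Homo sapiens) for cytotoxicity, read by MTT assay, with a stated time of 48 h (on this read-out lower numbers stand for stronger inhibition and higher numbers for weaker inhibition), gives 26200 nM. Among the numbers shown compound 1 stands highest; the nearest is compound 2 `O=C(Nc1ccc(S(=O)(=O)N2CCN(c3ccc(F)cc3)CC2)cc1)C1C(C(=O)O)[C@H]2CC[C@@H]1O2`, which in this assay gives 14400 nM, a gap that lies within the scatter of this read-out, so no order between the two can be claimed. Compound 3 `CCOC(=O)Cc1csc(NC(=O)C2C(C(=O)O)[C@H]3CC[C@@H]2O3)n1` returns in this assay only a limit, > 100000 nM, and not a number (the limit of > 100000 nM in this assay, at which 1 of the 3 values shown sits). Among the measured compounds shown here, no pair among the measured compounds differs in a single place, so no measured step is available to lean on.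

Compound 4 `O=C(Nc1ccc(S(=O)(=O)NC2CCCCC2)cc1)C1C(C(=O)O)[C@H]2CC[C@@H]1O2` is not yet measured. It differs from compound 1 by cyclohexyl in place of cyclopropyl on a sulfonamide nitrogen. With nothing measured on this kind of change, the expectation for this assay is a step of no more than modest size, if anything toward a lower number, and quite possibly none beyond the scatter. On that basis the estimate for compound 4 in this assay is 18000 nM, with a range from 6000 nM to 60000 nM. The step expected a 1.5-fold lower number from compound 1 to compound 4 (0.16 log units; within the scatter) is accordingly small, and the value stands open until measured.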

Compound 4, half-maximal inhibitory concentration: 22500 nM
For compound 4 the middle estimate is 1.3-fold (0.10 log units) below the measured one; low and high end bracket the measured number.
By their numbers in this assay, from the lowest: compounds 2, 4 and 1 (each within the scatter of the next). At a limit, above all of these: compound 3.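

Among the compounds shown here, compound 4 gives the only single-place step: on the sulfonamide nitrogen, cyclohexyl in place of cyclopropyl gives a 1.2-fold lower number from compound 1 to compound 4 (0.07 log units; within the scatter) in this assay. The earlier compounds shown here offered no such pair, and this one shows that this assay does not separate these two carbon-only rings at this position, even though the entering ring carries more heavy atoms than the one it replaces. Nothing shown here accounts for this outcome, and the single limit in the series has no bearing on this pair.

For the compounds shown here, with only one step at this position, and with both rings made of carbon alone and without hydrogen-bond donors or acceptors, the result says nothing about how a different kind of group on the sulfonamide nitrogen would read, such as a ring or chain carrying an amine, a hydroxyl group or a carboxylic acid, or a longer open chain. Going by these compounds, whether any change at this position can move the number beyond the scatter in this assay also remains open, as does whether this flat step would hold on a compound with a different group elsewhere on the shared core.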